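A Ring Swap on a Shared Core: Compound 3

The source may hold more compounds than are shown below. What is called first, only, known or untested is meant among the compounds shown, and "the series" means these compounds.

Compound 1, `CCCC[S+]([O-])c1sc2nc(-c3nccs3)cc(-c3ccc(CCO)cc3)c2c1N`, in an assay for inhibition of 15-hydroxyprostaglandin dehydrogenase [NAD(+)] (Homo sapiens), read by fluorescence, with a stated time of 15 min, in the presence of a further agent that is not named here (on this read-out lower numbers stand for stronger inhibition and higher numbers for weaker inhibition), gives 2.9 nM.
Compound 2, `CCCC[S+]([O-])c1sc2nc(-c3nccs3)cc(-c3ccc(CN)cc3)c2c1N`, in this assay gives 11.5 nM.

Compound 2 stands with the higher of the two numbers. For the measured compounds named here, the only measured step, a 4.0-fold higher number from compound 1 to compound 2 (0.60 log units; beyond the scatter), changes a group hanging from a ring, not the ring itself. Compound 3, `CCCC[S+]([O-])c1sc2nc(-c3nccs3)cc(-c3cnc(Cl)n3C)c2c1N`, differs from compound 2 by 2-chloro-1-methyl-1H-imidazol-5-yl in place of 4-(aminomethyl)phenyl on an aromatic carbon. Going by the values given here, no measured step exchanges a ring, so that step gives only loose guidance; the expected step is a 1.3-fold higher number from compound 2 to compound 3 (0.12 log units; within the scatter), with wide uncertainty. For compound 3 the estimate is 15 nM, expected between 3 nM and 80 nM.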

Compound 3, half-maximal inhibitory concentration: 3.2 nM
Estimate against measurement, compound 3: 4.7-fold (0.67 log units) above; measured number inside the range.
By their numbers in this assay, from the lowest: compounds 1 and 3 (each within the scatter of the next); then compound 2.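

Swapping the six-membered aromatic ring of carbon only for a five-membered aromatic ring with 2 hetero atoms does not cost inhibition at this position. Replacing 4-(aminomethyl)phenyl with 2-chloro-1-methyl-1H-imidazol-5-yl gives (a 3.6-fold lower number from compound 2 to compound 3 (0.56 log units; beyond the scatter)), while replacing 4-(2-hydroxyethyl)phenyl with it gives (a 1.1-fold higher number from compound 1 to compound 3 (0.04 log units; within the scatter)), so the new ring matches the hydroxyethyl compound and no side chain ending in an amine or hydroxyl is needed. Nothing shown here explains why. Still open, from the compounds shown here alone, is whether the chlorine or the methyl on the new ring matters, and how a pyridine ring would read at this position.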